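From an Open-Chain Group to a Methylpiperazine

The source may hold more compounds than are shown below. What is called first, only, known or untested is meant among the compounds shown, and "the series" means these compounds.

In a functional assay on SK-OV-3 cells (Homo sapiens) for cytotoxicity, read by MTT assay, with a stated time of 3 days (a lower number here means a stronger inhibitor, a higher number a weaker inhibitor), compound 1 `CNc1nc(SCc2nc3ccccc3[nH]2)nc(-c2ccccc2)c1C#N` gives 3 nM, and compound 2 `N#Cc1c(NNC(N)=S)nc(SCc2nc3ccccc3[nH]2)nc1-c1ccccc1` gives 3 nM, so compound 2 stands level with compound 1. Among the measured compounds shown here, the one measured step that bears on the next change is no change at the digits printed from compound 1 to compound 2 (within the scatter), and it altered the same group on the shared core. Compound 3 `CN1CCN(c2nc(SCc3nc4ccccc4[nH]3)nc(-c3ccccc3)c2C#N)CC1` carries a 4-methylpiperazin-1-yl group at this place, ortho to a cyano group: a group of 7 heavy atoms (5 carbon, 2 nitrogen; one six-membered non-aromatic ring with 2 hetero atoms) in place of a group of 5 heavy atoms (1 carbon, 3 nitrogen, 1 sulfur; no ring), on an aromatic carbon. For the measured compounds named here, no measured compound yet carries a ring at this place, so the evidence is thin and the new group goes beyond what has been tested. Even so, the single step gives no reason to expect a large shift in this assay. The expected result is a 1.3-fold higher number from compound 2 to compound 3 (0.12 log units; within the scatter), which is none beyond the scatter. For compound 3 the estimate is 4 nM, with an expected range of 1.5 nM to 15 nM.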

Compound 3, half-maximal inhibitory concentration: 1600 nM
Compound 3: middle estimate off by 400-fold (2.60 log units), on the low side; measured number outside the range, above it.
By their numbers in this assay, from the lowest: compounds 1 and 2 (each within the scatter of the next); then compound 3.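

In this assay this position proves far from indifferent to what it carries: compound 1 and compound 2 stand level despite their different open-chain groups, yet the ring-bearing 4-methylpiperazin-1-yl group gives a 530-fold higher number from compound 2 to compound 3 (2.73 log units; beyond the scatter) and, in place of methylamino, a 530-fold higher number from compound 1 to compound 3 (2.73 log units; beyond the scatter) in the same assay. The step from the thiosemicarbazide-type chain also swaps a group with 3 hydrogen-bond donors and no ring for one with 0 donors and a six-membered non-aromatic ring, so these differences change together and cannot be told apart here. Nothing measured here accounts for the size of this step.

The compounds shown leave open whether the ring itself or its methyl group goes with the higher number. A piperazin-1-yl group without the methyl, a morpholin-4-yl group or an open-chain dimethylamino group at this place would bear on that question.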